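The compounds below may be only part of what the source reports. "The series", "measured", "known", "first", "only" and "open" are said of these compounds alone.

Compound 1 `O=Cc1cn(-c2ccccc2)nc1-c1ccc(Cl)cc1` gives 15500 nM in a functional assay on HeLa cells (Homo sapiens) for antiproliferative activity, read by MTT assay, with a stated time of 48 h; a higher number here means a weaker inhibitor, a lower number a stronger inhibitor. Compound 2 `Clc1ccc2[nH]c(-c3cn(-c4ccccc4)nc3-c3ccccc3)nc2c1` gives 3480 nM in this assay, and compound 3 `Brc1ccc2[nH]c(-c3cn(-c4ccccc4)nc3-c3ccccc3)nc2c1` gives 1760 nM in this assay, the lowest of the three numbers, with compound 2 nearest, within the scatter, and compound 1 furthest, beyond it. For the measured compounds named here, the only measured step at this position is a 2.0-fold lower number from compound 2 to compound 3 (0.30 log units; within the scatter). Compound 4 `O=C(OCc1ccccc1)c1ccc2[nH]c(-c3cn(-c4ccccc4)nc3-c3ccccc3)nc2c1` differs from compound 3 by benzyloxycarbonyl in place of bromo on an aromatic carbon. Going by the values given here, no measured step exchanges a halogen for a benzyloxycarbonyl, so the halogen swap offers little guidance; the reasonable expectation is no step beyond the scatter in this assay, held with wide uncertainty. Compound 4 is therefore estimated at 2500 nM, within 700 nM to 9000 nM. The expected step is a 1.4-fold higher number from compound 3 to compound 4 (0.15 log units; within the scatter).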

Compound 4, half-maximal inhibitory concentration: 21300 nM
Estimate against measurement, compound 4: 8.5-fold (0.93 log units) below; the measured number lies above the stated range.
By their numbers in this assay, from the lowest: compounds 3 and 2 (each within the scatter of the next); then compounds 1 and 4 (each within the scatter of the next).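

The two halogens at this aromatic carbon gave no step beyond the scatter, but benzyloxycarbonyl does: this assay shows a 12-fold higher number from compound 3 to compound 4 (1.08 log units; beyond the scatter) and also a 6.1-fold higher number from compound 2 to compound 4 (0.79 log units; beyond the scatter). The position therefore does not accept every replacement, and the halogen pair gave no sign of this. No evidence at hand says which part of the entering group accounts for the rise. On these data alone, whether a methyl ester, a carboxylic acid or an amide at this carbon would stay near compound 3 remains open. So does whether the benzyl part or the carbonyl matters more.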